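Stereocentre swap in the acetyl-substituted urea

The compounds below may be only part of what the source reports. "The series", "measured", "known", "first", "only" and "open" are said of these compounds alone.

Two ureas have been measured in an ADME assay on the whole organism with Oryza sativa as the target, tested at 1 uM; on this read-out lower numbers stand for a stronger effect and higher numbers for a weaker effect at the one concentration tested. Compound 1 `Cc1cccc(NC(=O)N[C@@H](C)c2ccccc2)c1` gives 100%. Compound 2 `CC(=O)c1cccc(NC(=O)N[C@H](C)c2ccccc2)c1` gives 88%, the lowest of the two numbers; its nearest neighbour is compound 1, which lies higher by a gap beyond the scatter. For the measured compounds named here, the two measured compounds differ from each other in more than one place, so no single step between them can be read off.

Compound 3 `CC(=O)c1cccc(NC(=O)N[C@@H](C)c2ccccc2)c1` is not yet measured. Relative to compound 2, (the two compounds have the same atoms and bonds and differ only in configuration as drawn: 1 of 1 stereo elements differ; a stereocentre at a saturated chain carbon is drawn R in compound 2 and S in compound 3). Going by the values given here, no pair of measured compounds shows what such a change in drawn configuration does in this assay; compound 1 carries the same drawn configuration as compound 3 but also a different substituent, so it gives no isolated reading. The step of a number 5 percentage points higher from compound 2 to compound 3 (within the scatter) is therefore expected to be small, with the expectation leaning slightly upward. Compound 3 is estimated at 93%, within 80% to 100%.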

Compound 3, a percentage reported as activity, at one concentration (the size of the read-out at that concentration, not a potency): 95%
Beside the measured number, compound 3's estimate is 2 percentage points below it; the range from low to high includes it.
By their numbers in this assay, from the lowest: compounds 2, 3 and 1 (each within the scatter of the next, the first and the last beyond it).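

In this assay, the stereocentre at the saturated chain carbon now has its first isolated reading, a number 7 percentage points higher from compound 2 to compound 3 (within the scatter), so in the acetyl-substituted urea the R and S drawings cannot be told apart at the one concentration tested. Acetyl in place of methyl on an aromatic carbon, with the drawn configuration kept, also has its first isolated reading, a number 5 percentage points lower from compound 1 to compound 3 (within the scatter), so this change cannot be told from the scatter either. The first of these readings isolates configuration alone: the fact that compounds 2 and 3 differ only in the configuration as drawn

The compounds shown leave open whether the drawn configuration reads the same with methyl on the aromatic carbon in place of acetyl. Also open, on these data alone, is what a carboxylic acid or an amine on that aromatic carbon, or a longer chain at the stereocentre, would do in this assay.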